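Replacing hydroxymethyl by methylcarbamoyl on a nucleoside core

The source may report more compounds than this note shows. Statements on the series, on what has been measured and on what is new or still open speak of the compounds shown alone.

Four compounds share the adenine-type head of adenosine, joined to a bicyclic sugar-like core, and are compared in a functional assay for antagonist activity at adenosine receptor A3 (Homo sapiens), with a stated time of 30 min; on this read-out lower numbers stand for stronger inhibition and higher numbers for weaker inhibition. Compound 1 `Nc1ncnc2c1ncn2[C@@H]1O[C@@]2(CO)CO[C@@H]1[C@@H]2O` carries a hydroxymethyl group on its core. In this assay compound 1 gives > 100000 nM, which is a limit of the assay and not a number. Compound 2 `CNC(=O)[C@@]12CO[C@@H]([C@H](n3cnc4c(N)ncnc43)O1)[C@@H]2O` differs from compound 1 by methylcarbamoyl in place of hydroxymethyl on a saturated ring carbon. In this assay compound 2 gives > 100000 nM, again a limit rather than a number. The step that the two limits leave unreadable from compound 1 to compound 2 therefore cannot be read, because the limit of > 100000 nM in this assay, at which 2 of the 3 values shown sit, holds both ends of it.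

Compound 3 `OC[C@@]12CN[C@@H]([C@H](n3cnc4c(NCc5cccc(I)c5)ncnc43)O1)[C@@H]2O` has a different core and a larger group on the amine. The difference between the two cores is not broken down here. In this assay, going by the values given here, compound 3 gives 8.2 nM, the only value among the three that is a number.

Compound 4 `CNC(=O)[C@@]12CN[C@@H]([C@H](n3cnc4c(NCc5cccc(I)c5)ncnc43)O1)[C@@H]2O` has not yet been measured. It differs from compound 3 by methylcarbamoyl in place of hydroxymethyl on a saturated ring carbon. The surroundings are not the same as in the first pair: in compound 3 the ring holds one nitrogen, with the changed carbon two ring bonds from the ring nitrogen, whereas in compound 1 the ring holds one oxygen and the carbon sits next to the ring oxygen. So this is the same kind of change, not the same change. Among the compounds with values here, because the only measured example of it is a step that the two limits leave unreadable from compound 1 to compound 2, nothing readable about its size is available, so the estimated step from compound 3 to compound 4 is expected to be small, a 1.6-fold lower number from compound 3 to compound 4 (0.21 log units; within the scatter). Compound 4 is estimated to give 5 nM in this assay, expected to fall between 1.5 nM and 25 nM.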

Compound 4, half-maximal inhibitory concentration: 12 nM
Compound 4: the middle estimate sits 2.4-fold (0.38 log units) below what was measured, and the stated range covers the measured number.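

On the core of compound 3, methylcarbamoyl in place of hydroxymethyl gives, in this assay, a 1.5-fold higher number from compound 3 to compound 4 (0.17 log units; within the scatter), so the two values cannot be told apart and this one pair shows no readable effect of the change. The same change on the core of compound 1 gives no size to set against this one, because compound 1 and compound 2 both stand at a limit of the assay and not at a number: the limit of > 100000 nM in this assay, at which 2 of the 4 values shown sit. The new step therefore shows what the change does on one core only, and it does not show that the change behaves alike on the core of compound 1, where the ring holds an oxygen in place of the nitrogen and the amine lacks the larger group.

Still open, from the compounds shown here alone, is whether another group on that saturated ring carbon, such as a carboxylic acid or an amine, or a longer chain on the amide nitrogen, would also leave the number where compound 3 has it. Also open, going by these compounds, is how hydroxymethyl and methylcarbamoyl compare on the oxygen-containing core once its amine carries the larger group of compound 3, a pair that would give the change a second readable step.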